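Methoxy for Methyl on Two Related Cores

A few compounds are considered here, and "the series" means these few. Any claim that something is new, unique, unknown or untested is made for them only; others in the source may bear on it.

Compound 1 `CCOC(=O)c1csc2nc(CN3CCN(C)CC3)c(-c3ccc(C)cc3)n12` and compound 2 `CCOC(=O)c1csc2nc(CN3CCN(C)CC3)c(-c3ccc(OC)cc3)n12` share one core, while compound 3 `Cc1ccc(-c2c(CN3CCCCC3)nc3scc(C(=O)O)n23)cc1` and the still unmeasured compound 4 `COc1ccc(-c2c(CN3CCCCC3)nc3scc(C(=O)O)n23)cc1` share another; the difference between the two cores is not broken down here. In a functional assay on HeLa cells (Homo sapiens) for antiproliferative activity, read by MTT assay, with a stated time of 72 h (a higher number here means a weaker inhibitor, a lower number a stronger inhibitor), compound 1 gives 43900 nM, and compound 2 gives 35100 nM. In this assay compound 3 gives 7630 nM, the lowest of the three numbers, and its distance from compound 1 and from compound 2 lies beyond the scatter, so compound 3 is the strongest inhibitor of the measured set.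

The change from compound 1 to compound 2 is methoxy in place of methyl on an aromatic carbon. It made a 1.3-fold lower number from compound 1 to compound 2 (0.10 log units; within the scatter). The very same change, at a place described in identical words, takes compound 3 to compound 4: methoxy in place of methyl on an aromatic carbon. The two cores differ, but the position of the exchange on the aromatic ring is the same.

Among the measured compounds shown here, only one measured instance of this change exists, so the expectation rests on a thin base. Because a 1.3-fold lower number from compound 1 to compound 2 (0.10 log units; within the scatter) stayed within the scatter, compound 4 is expected to stand close to compound 3. In this assay compound 4 is therefore estimated at 6500 nM, with a range from 2500 nM to 17000 nM. The step this estimate means, placed beside the earlier one, is expected to be a 1.2-fold lower number from compound 3 to compound 4 (0.07 log units; within the scatter).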

Compound 4, half-maximal inhibitory concentration: 47400 nM
For compound 4 the middle estimate is 7.3-fold (0.86 log units) below the measured one; measured number outside the range, above it.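

In this assay, methoxy in place of methyl on the aromatic carbon gave a 6.2-fold higher number from compound 3 to compound 4 (0.79 log units; beyond the scatter). Set beside the earlier step, the same exchange does not carry over unchanged from one core to the other in this series: the same change on two cores in this assay, a 1.3-fold lower number (0.10 log units; within the scatter) from compound 1 to compound 2 and a 6.2-fold higher number (0.79 log units; beyond the scatter) from compound 3 to compound 4, 7.8-fold (0.89 log units) apart, beyond the scatter of two such steps This shows that the outcome of the 4-methylphenyl to 4-methoxyphenyl exchange on one core did not predict its outcome on the other, but with a single pair on each core it gives no rule for any further core and does not show which feature of the two cores is responsible.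

The compounds shown leave open whether a longer group such as ethoxy, or a halogen such as chlorine, on that same aromatic carbon would give a number closer to that of compound 3 or to that of compound 4. They also leave open whether an amide in place of the carboxylic acid shared by compound 3 and compound 4 would preserve the step seen with the acid.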